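Adding 2,4-dichlorobenzyl to compound 2

This account rests on a few compounds, and the source may have more. Where it says the series, first, only, none or still open, it means among the compounds named here.

Measured in a functional assay on MDA-MB-231 cells (Homo sapiens) for cytotoxicity, read by MTT assay, with a stated time of 72 h; a higher number here means a weaker inhibitor, a lower number a stronger inhibitor
Compound 1 `CN(C)Cc1ccc2nc(NC(=O)N/N=C/c3cn(Cc4ccc(C(C)(C)C)cc4)c4ccccc34)sc2c1` gives 2230 nM
Compound 2 `CN(C)Cc1ccc2nc(NC(=O)N/N=C/c3c[nH]c4ccccc34)sc2c1` gives 1190 nM

Within the data shown here, compound 2 stands level with compound 1, the only other measured compound, as the two values lie within the scatter of each other. Compound 3 `CN(C)Cc1ccc2nc(NC(=O)N/N=C/c3cn(Cc4ccc(Cl)cc4Cl)c4ccccc34)sc2c1` carries 2,4-dichlorobenzyl in place of hydrogen on an aromatic nitrogen of compound 2 (2,4-dichlorobenzyl in place of hydrogen on an aromatic nitrogen). Among the measured compounds shown here, one measured step bears on this, hydrogen in place of 4-(tert-butyl)benzyl on an aromatic nitrogen (a 1.9-fold lower number from compound 1 to compound 2 (0.27 log units; within the scatter)). Going by compound 1, which gives 2230 nM, no step beyond the scatter is expected in this assay, with a slight lean toward a higher number. The expected step is a 1.5-fold higher number from compound 2 to compound 3 (0.18 log units; within the scatter) and it should stay small. Compound 3 is expected at 1800 nM (estimated range 700 nM to 4500 nM).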

Compound 3, half-maximal inhibitory concentration: 1410 nM
Compound 3: the middle estimate sits 1.3-fold (0.11 log units) above what was measured, within the range that was stated.
By their numbers in this assay, from the lowest: compounds 2, 3 and 1 (each within the scatter of the next).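

In this assay, 2,4-dichlorobenzyl on the aromatic nitrogen stays within the scatter of the unsubstituted compound (a 1.2-fold higher number from compound 2 to compound 3 (0.07 log units; within the scatter)), as 4-(tert-butyl)benzyl did. Exchanging one benzyl group for the other also stays within the scatter (a 1.6-fold lower number from compound 1 to compound 3 (0.20 log units; within the scatter)), so hydrogen and both benzyl groups cannot be told apart at this position in compound 1, compound 2 and compound 3. No measurement shown explains this result. Still open, on these data alone, is whether a different kind of group on this nitrogen, such as a simple methyl, an aminoethyl chain or a carboxylic acid on a longer chain, would give a step beyond the scatter.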